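Bromo for Cyano on the Fused Core of Compound 2

The source may hold more compounds than are shown below. What is called first, only, known or untested is meant among the compounds shown, and "the series" means these compounds.

Of the compounds shown here, two have been measured in a functional assay on the whole organism with Rattus norvegicus as the target, with a stated time of 4 h, at a dose of 40 mg/kg by the intraperitoneal route; on this read-out lower numbers stand for less inhibition and higher numbers for more inhibition at the one dose given (going by the name of the read-out). Compound 1, `Cc1nc2c(C[S+]([O-])c3ccccc3)cccn2c1C`, gives 42% in this assay. Compound 2, `Cc1nc2c(OCc3ccccc3)cccn2c1C#N`, gives 25% in this assay, the lower of the two numbers, and compound 1 stands higher by a gap that lies beyond the usual scatter. Compound 3, `Cc1nc2c(OCc3ccccc3)cccn2c1Br`, has not yet been measured. It differs from compound 2 in a single place: bromo in place of cyano on an aromatic carbon. Within the data shown here, no pair of measured compounds shares this change, so nothing measured shows how it acts in this assay. The step of a number 7 percentage points higher from compound 2 to compound 3 (within the scatter) is therefore expected to be small, upward if anything, and not beyond the scatter. For compound 3 an inhibition of 32% is estimated, with a range from 12% to 52%.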

Compound 3, a percentage reported as inhibition, in the whole organism at one dose (the size of the read-out at that dose, not a potency): 26%
Compound 3: the middle estimate sits 6 percentage points above what was measured, within the range that was stated.
By their numbers in this assay, from the lowest: compounds 2 and 3 (each within the scatter of the next); then compound 1.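

Bromo in place of cyano on this aromatic carbon of the five-membered aromatic ring gives a number 1 percentage points higher from compound 2 to compound 3 (within the scatter) in this assay, the first one-place comparison among these compounds. At this position, next to the ring nitrogen and next to the ring atom that bears a methyl group, the read-out thus stays within the scatter when the nitrile, with its triple bond and hydrogen-bond acceptor, gives way to a bromo group with neither. Nothing available explains why these two groups read alike.

The compounds shown leave open whether an amine, a carboxylic acid or a longer chain at this position would move the read-out beyond the scatter. They also leave open whether the same match between bromo and cyano would hold at another dose or time.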